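Chloro in place of methoxy: expected cytotoxicity step

This account rests on a few compounds, and the source may have more. Where it says the series, first, only, none or still open, it means among the compounds named here.

Compound 1 `c1ccc(NN=C(c2nc3ccccc3[nH]2)c2nc3ccccc3[nH]2)cc1` gives 144000 nM in a functional assay on K562 cells (Homo sapiens) for cytotoxicity, read by MTT assay, with a stated time of 72 h; a lower number here means a stronger inhibitor, a higher number a weaker inhibitor. Compound 2 `COc1ccc(NN=C(c2nc3ccccc3[nH]2)c2nc3ccccc3[nH]2)cc1` gives 235000 nM in this assay; the step of a 1.6-fold higher number from compound 1 to compound 2 (0.21 log units; within the scatter) adds a methoxy group. For the measured compounds named here, compound 2 thus stands alongside compound 1 on the numbers so far, with the gap between the two within the scatter. Compound 3 `Clc1ccc(NN=C(c2nc3ccccc3[nH]2)c2nc3ccccc3[nH]2)cc1` differs from compound 2 by chloro in place of methoxy on an aromatic carbon, para to a large group. Going by the values given here, only the step from compound 1 to compound 2 touches this same aromatic carbon, and it stayed within the scatter, so a change of a small group at this place has so far moved this assay little. A step of no size beyond the scatter is therefore expected, a 1.3-fold lower number from compound 2 to compound 3 (0.12 log units; within the scatter). Compound 3 is estimated at 180000 nM, within 80000 nM to 400000 nM.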

Compound 3, half-maximal inhibitory concentration: 159000 nM
For compound 3 the middle estimate is 1.1-fold (0.05 log units) above the measured one; measured number inside the range.
By their numbers in this assay, from the lowest: compounds 1, 3 and 2 (each within the scatter of the next).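

In this assay, chloro on this aromatic carbon, para to a large group, now stands with hydrogen and methoxy, and both new steps lie within the scatter: a 1.5-fold lower number from compound 2 to compound 3 (0.17 log units; within the scatter) for chloro in place of methoxy, and a 1.1-fold higher number from compound 1 to compound 3 (0.04 log units; within the scatter) for chloro in place of hydrogen. Across compound 1, compound 2 and compound 3, neither the loss of the methoxy oxygen, a hydrogen-bond acceptor, nor the entry of a chlorine separates the compounds beyond the scatter. No measurement at hand accounts for this flat reading.

Going by these compounds, whether any group on this carbon can move the number beyond the scatter remains open, for example an amine, a carboxylic acid or a longer chain. Also open, on these data alone, is how the same exchanges read at other carbons of this ring or with changes to the shared core.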